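The compounds below may be only part of what the source reports. "The series", "measured", "known", "first", "only" and "open" are said of these compounds alone.

Measured in a physicochemical assay for solubility, read by HPLC, measured as thermodynamic solubility, with a stated time of 4 h, at pH 6.8; a higher number here means a more soluble compound, a lower number a less soluble compound:
compound 1 `Cn1c(COc2cccc(C(=O)O)c2)nc2ccc(Oc3ccccn3)cc21` gives 62 ug/mL;
compound 2 `Cn1c(COc2cccc(C(=O)O)c2)nc2ccc(Oc3cc(Cl)ccn3)cc21` gives 11 ug/mL;
compound 3 `Cn1c(COc2cccc(C(=O)O)c2)nc2ccc(Oc3ncccc3Cl)cc21` gives 15 ug/mL.

Compound 3 stands second highest of the three in this assay; its nearest neighbour is compound 2 (a 1.4-fold higher number from compound 2 to compound 3 (0.13 log units; within the scatter)), its furthest compound 1 (a 4.1-fold lower number from compound 1 to compound 3 (0.62 log units; beyond the scatter)).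

Compound 4 `Cc1ccnc(Oc2ccc3nc(COc4cccc(C(=O)O)c4)n(C)c3c2)c1` differs from compound 3 by 4-methylpyridin-2-yl in place of 3-chloropyridin-2-yl on an oxygen on an aromatic ring. For the measured compounds named here, no measured pair shows methyl in place of chloro, so no step bears on it directly. The two steps that add chloro to the ring on the oxygen, a 5.6-fold lower number from compound 1 to compound 2 (0.75 log units; beyond the scatter) and a 4.1-fold lower number from compound 1 to compound 3 (0.62 log units; beyond the scatter), were modest and both downward; removing the chloro may recover part of that, but the entering methyl is an unknown here.

For compound 4 in this assay a value of 22 ug/mL is expected, within 8 ug/mL to 55 ug/mL. The expected step is a 1.5-fold higher number from compound 3 to compound 4 (0.17 log units; within the scatter), which may fall inside the scatter.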

Compound 4, solubility: 33 ug/mL
The estimate for compound 4 lay 1.5-fold (0.18 log units) below the measured number, within the range that was stated.
By their numbers in this assay, from the lowest: compounds 2 and 3 (each within the scatter of the next); then compounds 4 and 1 (each within the scatter of the next).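

In this assay, for the compounds shown here, the pair carrying 4-chloropyridin-2-yl and 4-methylpyridin-2-yl gives the first direct reading of methyl in place of chloro on an aromatic carbon (a 3.0-fold higher number from compound 2 to compound 4 (0.48 log units; beyond the scatter)), and the change from 3-chloropyridin-2-yl also lies beyond the scatter (a 2.2-fold higher number from compound 3 to compound 4 (0.34 log units; beyond the scatter)). Methyl in place of hydrogen stays within the scatter (a 1.9-fold lower number from compound 1 to compound 4 (0.27 log units; within the scatter)), whereas both chloro steps from compound 1 lay beyond it. No measurement here accounts for these differences.

Open, from the compounds shown here alone, is whether an amine or a methoxy group on this pyridine would follow methyl or chloro. Also open, going by these compounds, is whether a longer chain would stay within the scatter of compound 1.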